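Swapping the aryl group on the dioxane core: toward naphthyl

The source may hold more compounds than are shown below. What is called first, only, known or untested is meant among the compounds shown, and "the series" means these compounds.

Measured compounds:
- compound 1, `O=C(O)CC/C=C\CC1COC(c2ccc(Cl)cc2Cl)OC1c1cccnc1`: 42 nM
- compound 2, `O=C(O)CC/C=C\CC1COC(c2ccsc2)OC1c1cccnc1`: 500 nM
- compound 3, `O=C(O)CC/C=C\CC1COC(c2ccco2)OC1c1cccnc1`: 164 nM

All three share a core in which a saturated ring carbon between two ring oxygen atoms carries an aromatic group, and they differ only in that group. In an assay for inhibition of Thromboxane-A synthase (Homo sapiens), using microsomes (on this read-out lower numbers stand for stronger inhibition and higher numbers for weaker inhibition), compound 3 stands second highest of the three numbers: it sits a 3.0-fold lower number from compound 2 to compound 3 (0.48 log units; beyond the scatter) and a 3.9-fold higher number from compound 1 to compound 3 (0.59 log units; beyond the scatter). The step to compound 4, `O=C(O)CC/C=C\CC1COC(c2ccc3ccccc3c2)OC1c1cccnc1`, is naphthalen-2-yl in place of furan-2-yl on a saturated ring carbon.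

Within the data shown here, two measured steps bear on this change. Moving from the furan-2-yl of compound 3 back to the 2,4-dichlorophenyl of compound 1 gave a modest step, and replacing thiophen-3-yl with furan-2-yl gave another modest step, so the group on this carbon clearly matters. Among the measured compounds shown here, compound 1, the only compound with a six-membered carbon-only aromatic ring here, has the lowest number, and naphthalen-2-yl brings two such rings. A modest step downward in this assay is therefore expected for compound 4, roughly a 2.3-fold lower number from compound 3 to compound 4 (0.37 log units; beyond the scatter). The estimate for compound 4 is 70 nM, expected to fall between 25 nM and 200 nM.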

Compound 4, half-maximal inhibitory concentration: 50 nM
Beside the measured number, compound 4's estimate is 1.4-fold (0.15 log units) above it, within the range that was stated.
By their numbers in this assay, from the lowest: compounds 1 and 4 (each within the scatter of the next); then compound 3; then compound 2.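

In this assay, naphthalen-2-yl clearly outperforms both groups with a five-membered aromatic ring, the furan-2-yl of compound 3 (a 3.3-fold lower number from compound 3 to compound 4 (0.52 log units; beyond the scatter)) and the thiophen-3-yl of compound 2 (a 10-fold lower number from compound 2 to compound 4 (1.00 log units; beyond the scatter)). Against 2,4-dichlorophenyl the comparison gives (a 1.2-fold higher number from compound 1 to compound 4 (0.08 log units; within the scatter)), so a group with two six-membered aromatic rings of carbon only and no chlorine sits level with a single such ring carrying two chlorines, showing that chlorine is not required for a number of this size at this position. In all four compounds, the groups with six-membered carbon-only aromatic rings give lower numbers than those with five-membered rings, but no measurement here explains that difference. The compounds shown leave open whether an unsubstituted phenyl group would match compounds 1 and 4. They also leave open how naphthalen-1-yl, or an amine or methoxy group added to the naphthalene, would change the number.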